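This account rests on a few compounds, and the source may have more. Where it says the series, first, only, none or still open, it means among the compounds named here.

Of the compounds shown here, two have numbers so far. In an assay on ileum (strain Hartley) with 5-hydroxytryptamine receptor 3A (Cavia porcellus) as the target (a lower number here means a smaller maximal response, a higher number a larger maximal response), compound 1 `CN1CCN(c2nc3cc([N+](=O)[O-])ccc3o2)CC1` gives 0.52, the larger of the two; compound 2 `CN1CCN(c2nc3cc(Cl)cc(Cl)c3o2)CC1` gives 0.14, a gap that lies beyond the usual scatter. Compound 3 `CN1CCN(c2nc3cc(Br)ccc3o2)CC1` has not been measured. It differs from compound 1 by bromo in place of nitro on an aromatic carbon. Within the data shown here, no step between measured compounds isolates this change, so the expectation rests only on compound 2 standing at 0.14 with halogens in place of the nitro group. A drop is expected, with the step from compound 1 to compound 3 estimated at a number 0.22 lower from compound 1 to compound 3 (beyond the scatter). Compound 3 is thus estimated to reach 0.3, within 0.1 to 0.55.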

Compound 3, intrinsic activity: the largest response reached, as a fraction of the reference agonist's: 0.48
Estimate against measurement, compound 3: 0.18 below, within the range that was stated.
By their numbers in this assay, from the lowest: compound 2; then compounds 3 and 1 (each within the scatter of the next).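

In this assay bromo in place of nitro on an aromatic carbon gives a number 0.040 lower from compound 1 to compound 3 (within the scatter) and so no distinction between the two groups at this position. The nitro group is therefore not needed for a maximal response of this size, and the hydrogen-bond acceptors counted on it are absent from bromo without a readable difference. Nothing on hand offers a reason for this.

Still open, going by these compounds, is whether an amine or a carboxylic acid on this aromatic carbon would keep the response, and how a single chloro there would compare with bromo.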